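The source may hold more compounds than are shown below. What is called first, only, known or untested is meant among the compounds shown, and "the series" means these compounds.

Measured compounds in a functional assay on MCF7 cells (Homo sapiens) for inhibition, read by XTT assay, with a stated time of 48 h; a higher number here means a weaker inhibitor, a lower number a stronger inhibitor:
compound 1 `COc1ccc(C(=O)/C(=C/c2ccc(Cl)cc2)CCOC(C)=O)cc1`: > 100000 nM
compound 2 `COc1ccc(C(=O)/C(=C/c2ccc(Cl)cc2Cl)CC(C)OC(C)=O)cc1`: > 100000 nM
compound 3 `COc1ccc(C(=O)/C(=C/C2CCCCC2)CC(C)OC(C)=O)cc1`: > 100000 nM

Compound 3 gives only a limit of this assay, not a number. Compound 1 likewise sits at a limit. Compound 2 likewise sits at a limit. All three values therefore share (the limit of > 100000 nM in this assay, at which 3 of the 3 values shown sit), so no ordering among them can be read. Going by the values given here, the one measured step that bears on the change under consideration is a step that the two limits leave unreadable from compound 2 to compound 3, which the two limits leave without a readable size or direction.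

Compound 4 `COc1ccc(C(=O)/C(=C/c2ccc(Cl)cc2)CC(C)OC(C)=O)cc1` differs from compound 3 by 4-chlorophenyl in place of cyclohexyl on a double-bonded chain carbon bound to a double-bonded chain carbon. Compound 4 also shares its core and chain with compound 1 and compound 2, both of which sit at a limit in this assay. The expected step is a step that the limit leaves unreadable from compound 3 to compound 4, meaning no movement this assay could read. Compound 4 is expected at 150000 nM, within a range from 50000 nM to 1000000 nM, and most likely reported again only as a limit of this assay.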

Compound 4, half-maximal inhibitory concentration: > 100000 nM
Compound 4 was reported as a limit; the forecaster's own chance of this, stated with the estimate: 85%; the middle value does not contradict the limit.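

In this assay compound 4 gives > 100000 nM, a limit and not a number. No step to compound 4 from compound 1, compound 2 or compound 3 can be read: the limit of > 100000 nM in this assay, at which 4 of the 4 values shown sit.

On these data alone, whether any of these changes on the shared core alters inhibition in this assay remains open.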